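Swapping the acrylamide tail of compound 1 for a piperidine

A few compounds are considered here, and "the series" means these few. Any claim that something is new, unique, unknown or untested is made for them only; others in the source may bear on it.

Compound 1 `COc1cc2ncnc(N3CCc4ccccc43)c2cc1NC(=O)/C=C/C(C)C` sits in the middle of the three measured numbers in a functional assay on MCF7 cells (Homo sapiens) for antiproliferative activity, read by MTT assay, with a stated time of 72 h; on this read-out lower numbers stand for stronger inhibition and higher numbers for weaker inhibition: compound 1 gives 6780 nM. Compound 2 `CC(C)/C=C/C(=O)Nc1cc2c(N3CCc4ccccc43)ncnc2cc1O[C@@H]1CCOC1` gives 9880 nM and compound 3 `COc1cc2ncnc(N3CCCc4ccccc43)c2cc1NC(=O)/C=C/C(C)C` gives 4290 nM; the steps of a 1.5-fold higher number from compound 1 to compound 2 (0.16 log units; within the scatter) and a 1.6-fold lower number from compound 1 to compound 3 (0.20 log units; within the scatter) are both within the scatter. Compound 4 `COc1cc2ncnc(N3CCc4ccccc43)c2cc1NC(=O)/C=C/CN1CCCCC1` differs from compound 1 by (piperidin-1-yl)methyl in place of isopropyl on a double-bonded chain carbon bound to a double-bonded chain carbon. Neither measured step touches this end of the chain, so nothing here shows how that part matters; the two steps only show that changes elsewhere moved the number little. The expected step is therefore modest and uncertain: a 1.4-fold lower number from compound 1 to compound 4 (0.13 log units; within the scatter). Compound 4 is estimated to give 5000 nM, in a range from 1500 nM to 15000 nM.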

Compound 4, half-maximal inhibitory concentration: 1680 nM
The estimate for compound 4 lay 3.0-fold (0.47 log units) above the measured number; the measured number falls inside the stated range.
By their numbers in this assay, from the lowest: compound 4; then compounds 3, 1 and 2 (each within the scatter of the next, the first and the last beyond it).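

In this assay, going by these compounds alone, the far end of this chain turns out to matter: a 4.0-fold lower number from compound 1 to compound 4 (0.61 log units; beyond the scatter) is the only step so far beyond the scatter, while the changes at the other two places stayed within it. The swap brings in a nitrogen and a six-membered ring together, so their contributions cannot be separated here. No evidence available explains the lower number. Going by these compounds, whether an open-chain amine such as dimethylamino, or a morpholine ring, would act like piperidine at this place remains open. So does whether the same swap would give a similar step starting from compound 2 or compound 3.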